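Methylamide to carboxylic acid on a CDK8 acrylamide core

The compounds below may be only part of what the source reports. "The series", "measured", "known", "first", "only" and "open" are said of these compounds alone.

Measured compounds:
- compound 1 `CNC(=O)/C=C/c1ccncc1-c1ccc2ccccc2c1`: 12.4 nM
- compound 2 `CCOC(=O)/C=C/c1ccncc1-c1ccc2[nH]ccc2c1`: 107 nM
- compound 3 `NC(=O)/C=C/c1ccncc1Nc1ccc(F)cc1`: "not determined" (no result reported)

In an assay on a protein complex for inhibition of CDK8/Cyclin C (Homo sapiens), with a stated time of 1 h (a lower number here means a stronger inhibitor, a higher number a weaker inhibitor), compound 1 gives the lowest of the two reported numbers; its nearest neighbour, compound 2, sits well beyond the scatter above it, and compound 3 carries no number. Compound 4 `O=C(O)/C=C/c1ccncc1-c1ccc2ccccc2c1` differs from compound 1 in one place: hydroxy in place of methylamino on a carbonyl carbon. Among the measured compounds shown here, no pair of measured compounds shows this change alone, so its effect is not known here. Trading the methylamino group for hydroxy removes the amide as such, and the expected outcome is a weakening, with the step of a 4.8-fold higher number from compound 1 to compound 4 (0.68 log units; beyond the scatter) estimated to lie beyond the scatter. Compound 4 is therefore expected to reach about 60 nM in this assay, within a range from 15 nM to 300 nM.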

Compound 4, half-maximal inhibitory concentration: 5 nM
Compound 4: the middle estimate sits 12-fold (1.08 log units) above what was measured; measured number below the stated range.
By their numbers in this assay, from the lowest: compound 4; then compound 1; then compound 2.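

In this assay the carbonyl carbon does not depend on the methylamino group for a low number: hydroxy in its place gives a 2.5-fold lower number from compound 1 to compound 4 (0.39 log units; beyond the scatter) and the step is modest but beyond the scatter. The change from methylcarbamoyl to carboxy is therefore a gain on the core of compound 1, not a loss. No evidence is available on why the number falls.

Going by these compounds, what a primary amide or an ethyl ester would give on the core of compound 1 remains open. So does whether the step carries over to the core of compound 2.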